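The source may report more compounds than this note shows. Statements on the series, on what has been measured and on what is new or still open speak of the compounds shown alone.

Compound 1, `O=C(/C=C/c1cccc(OCc2ccccc2)c1)c1ccc(Cl)cc1Cl`, is the starting point. Going by the values given here, in an ADME assay on HEK293 cells (Homo sapiens) for cytotoxicity, read by MTT assay, with a stated time of 68 h (a lower number here means a stronger inhibitor, a higher number a weaker inhibitor), compound 1 gives 24900 nM, the highest of the three numbers measured so far. Compound 2, `O=C(/C=C/c1cccc(OCc2ccccc2)c1)c1ccccc1Br`, gives 2200 nM in this assay, and compound 3, `O=C(/C=C/c1cccc(OCc2ccccc2)c1)c1ccc(Cl)c(Cl)c1Cl`, gives 2400 nM. Both steps away from compound 1 are large: an 11-fold lower number from compound 1 to compound 2 (1.05 log units; beyond the scatter) and a 10-fold lower number from compound 1 to compound 3 (1.02 log units; beyond the scatter). Between the two alternatives the step is a 1.1-fold higher number from compound 2 to compound 3 (0.04 log units; within the scatter).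

Compound 4, `O=C(/C=C/c1cccc(OCc2ccccc2)c1)c1cccc(Br)c1`, carries the change (3-bromophenyl in place of 2,4-dichlorophenyl on a carbonyl carbon). Among the compounds with values here, the step that bears most directly on it is the one to compound 2, where a bromophenyl likewise replaced the 2,4-dichlorophenyl and the number fell by an 11-fold lower number from compound 1 to compound 2 (1.05 log units; beyond the scatter). The bromine in compound 4 sits on a different carbon of that ring, so the size of the step is less certain, but a lower number is expected, of roughly a 5.0-fold lower number from compound 1 to compound 4 (0.70 log units; beyond the scatter). Compound 4 is therefore estimated at 5000 nM in this assay, with a likely range of 1500 nM to 16000 nM.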

Compound 4, half-maximal inhibitory concentration: 7100 nM
Compound 4: middle estimate off by 1.4-fold (0.15 log units), on the low side; low and high end bracket the measured number.
By their numbers in this assay, from the lowest: compounds 2 and 3 (each within the scatter of the next); then compound 4; then compound 1.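

In this assay, the two bromophenyl rings are not interchangeable on the carbonyl carbon: 3-bromophenyl in place of 2-bromophenyl gives a 3.2-fold higher number from compound 2 to compound 4 (0.51 log units; beyond the scatter) and so puts the placing of the bromine beyond the scatter. Against the starting point, 3-bromophenyl in place of 2,4-dichlorophenyl still gives a 3.5-fold lower number from compound 1 to compound 4 (0.54 log units; beyond the scatter) but falls short of the earlier drops, and 3-bromophenyl in place of 2,3,4-trichlorophenyl gives a 3.0-fold higher number from compound 3 to compound 4 (0.47 log units; beyond the scatter) as well. Nothing at hand accounts for these differences.

Going by these compounds, all four compounds carry only halogens on this ring, so it remains open whether an amine or a carboxylic acid in place of the bromine would shift the number. Whether a single chloro would track the bromine also stays unresolved.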